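The compounds below may be only part of what the source reports. "The series", "measured", "known", "first", "only" and "open" are said of these compounds alone.

In an assay for inhibition of Tryptophan 2,3-dioxygenase (Homo sapiens), with stated times of 10 min and 60 min, tested at 10 uM (on this read-out higher numbers stand for a stronger effect at the one concentration tested and lower numbers for a weaker effect), compound 2 `O=[N+]([O-])c1ccc(Cl)cc1CNc1cc(C(F)(F)F)cc2[nH]ncc12` gives 84%, the highest of the two numbers recorded. Compound 1 `O=[N+]([O-])c1cc(OCc2ccccc2)ccc1CNc1cc(C(F)(F)F)cc2[nH]ncc12` gives 49%, a gap beyond the usual scatter. Compound 3 `O=[N+]([O-])c1ccccc1CNc1cc(C(F)(F)F)cc2[nH]ncc12` has not been measured; it differs from compound 2 by hydrogen in place of chloro on an aromatic carbon. For the measured compounds named here, no measured pair shows this change, so a moderate downward step is expected rather than none, because compound 2 already gives 84%. Compound 1 with 49% shows the shared core can sit well lower. Compound 3 is estimated at 60%, within 30% to 85%. For compound 3 the expected step is a number 24 percentage points lower from compound 2 to compound 3 (beyond the scatter).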

Compound 3, a percentage reported as inhibition, at one concentration (the size of the read-out at that concentration, not a potency): 89%
Compound 3: middle estimate off by 29 percentage points, on the low side, outside the stated range (above it).
By their numbers in this assay, from the lowest: compound 1; then compounds 2 and 3 (each within the scatter of the next).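

In this assay, hydrogen in place of the chloro para to a nitro group gives a number 5 percentage points higher from compound 2 to compound 3 (within the scatter), so the two compounds cannot be told apart and the chloro is not needed to hold the read-out. Hydrogen in place of benzyloxy gives a number 40 percentage points higher from compound 1 to compound 3 (beyond the scatter), so the large substituent, not the shared core, goes with the lower number. No measurement shown explains either step. The compounds leave open whether an amine, a carboxylic acid or a methoxy group on this carbon would hold the read-out as well.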